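A few compounds are considered here, and "the series" means these few. Any claim that something is new, unique, unknown or untested is made for them only; others in the source may bear on it.

Of the compounds shown here, three of a shared core have been measured in a functional assay (Pituitary gland cell) with Rattus norvegicus as the target; on this read-out lower numbers stand for an effect already at smaller amounts and higher numbers for an effect only at larger amounts of compound. Compound 1 `Cc1ccccc1-c1ccc(CN2C(=O)[C@H](NC(=O)CC(C)(C)N)CCc3ccccc32)cc1` gives 1 uM. Compound 2 `Cn1nnc(-c2ccccc2-c2ccc(CN3C(=O)[C@H](NC(=O)CC(C)(C)N)CCc4ccccc43)cc2)n1` gives 0.3 uM, and the step of a 3.3-fold lower number from compound 1 to compound 2 (0.52 log units; beyond the scatter) is modest. Compound 3 `CC(O)Cn1nnc(-c2ccccc2-c2ccc(CN3C(=O)[C@H](NC(=O)CC(C)(C)N)CCc4ccccc43)cc2)n1` gives 0.05 uM, the lowest of the three numbers; the step of a 20-fold lower number from compound 1 to compound 3 (1.30 log units; beyond the scatter) is large, and the step of a 6.0-fold lower number from compound 2 to compound 3 (0.78 log units; beyond the scatter) is modest.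

Compound 4 `CC(C)(N)CC(=O)N[C@@H]1CCc2ccccc2N(Cc2ccc(-c3ccccc3C(=O)O)cc2)C1=O` has not yet been measured. It differs from compound 3 in one place: carboxy in place of 2-(2-hydroxypropyl)-2H-tetrazol-5-yl on an aromatic carbon. The whole five-membered aromatic ring with its side chain is gone and a small group takes its place on the same aromatic carbon. The measured steps all run toward the tetrazole and its side chain, so removing both is expected to undo much of that gain. The step from compound 1 to compound 2 suggests the ring alone mattered modestly, and the step from compound 2 to compound 3 that the side chain mattered further. For compound 4 the expected step is a 10-fold higher number from compound 3 to compound 4 (1.00 log units; beyond the scatter). Compound 4 is therefore estimated at 0.5 uM, within the range 0.1 uM to 3 uM.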

Compound 4, concentration for half-maximal effect: 3 uM
Compound 4: the middle estimate sits 6.0-fold (0.78 log units) below what was measured, within the range that was stated.
By their numbers in this assay, from the lowest: compound 3; then compound 2; then compound 1; then compound 4.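

In this assay, a larger group at this aromatic carbon does not by itself lower the number: with carboxy in place of methyl there is a 3.0-fold higher number from compound 1 to compound 4 (0.48 log units; beyond the scatter) and so the change runs opposite to the steps from methyl to the two tetrazole groups. Set against those groups, carboxy shows a wider gap, with a 10-fold higher number from compound 2 to compound 4 (1.00 log units; beyond the scatter) and a 60-fold higher number from compound 3 to compound 4 (1.78 log units; beyond the scatter) as the two readings, and compound 4 has the highest number of the four. So this one place separates the four groups clearly, and the kind of group on it matters, not merely its presence; nothing measured here explains why.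

Open, going by these compounds, is how a primary amide, a methyl ester or a carboxymethyl group would read on this aromatic carbon. Also open, on these data alone, is whether a tetrazol-5-yl ring with only hydrogen on its nitrogen would fall nearer compound 2 or compound 4.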